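Methoxy in place of bromo on the phenyl ring of compound 2

The source may report more compounds than this note shows. Statements on the series, on what has been measured and on what is new or still open speak of the compounds shown alone.

Two compounds of the series have numbers in a functional assay on HepG2 cells (Homo sapiens) for inhibition, read by CCK-8 assay, with a stated time of 48 h; on this read-out higher numbers stand for weaker inhibition and lower numbers for stronger inhibition. Compound 1 `O=C1CSC(N2N=C(c3ccc(F)cc3)CC2c2cccc3ccccc23)=N1` gives 19500 nM in this assay. Compound 2 `O=C1CSC(N2N=C(c3ccc(Br)cc3)CC2c2cccc3ccccc23)=N1` gives 13400 nM in this assay. The step of a 1.5-fold lower number from compound 1 to compound 2 (0.16 log units; within the scatter) is the only one measured so far, and it lies within the scatter; compound 2 therefore stands at the lower of the two numbers without being separated from compound 1 beyond the scatter.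

Compound 3 `COc1ccc(C2=NN(C3=NC(=O)CS3)C(c3cccc4ccccc34)C2)cc1` is the next member. It differs from compound 2 in one place: methoxy in place of bromo on an aromatic carbon. Going by the values given here, the only measured step that bears on this change is the earlier exchange at the same aromatic carbon, a 1.5-fold lower number from compound 1 to compound 2 (0.16 log units; within the scatter), which stayed within the scatter. Among the compounds with values here, no measured compound carries a methoxy at this carbon, so the size of the present change in this assay is not known from the series itself. The expected step is a 1.1-fold higher number from compound 2 to compound 3 (0.05 log units; within the scatter), that is, no movement beyond the scatter in either direction. For compound 3 the estimate in this assay is 15000 nM, with a range from 5000 nM to 45000 nM.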

Compound 3, half-maximal inhibitory concentration: 7850 nM
Compound 3: the middle estimate sits 1.9-fold (0.28 log units) above what was measured, and the stated range covers the measured number.
By their numbers in this assay, from the lowest: compounds 3, 2 and 1 (each within the scatter of the next, the first and the last beyond it).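

In this assay, the exchange at this aromatic carbon now produces a step beyond the scatter, though a modest one: a 2.5-fold lower number from compound 1 to compound 3 (0.40 log units; beyond the scatter). The step from the bromo compound stays within the scatter, at a 1.7-fold lower number from compound 2 to compound 3 (0.23 log units; within the scatter), so methoxy is separated from fluoro but not from bromo, and only the two ends of the series stand apart. The position thus accepts a group with two heavy atoms and one hydrogen-bond acceptor as well as a single halogen atom, but nothing measured accounts for the separation between the fluoro and methoxy compounds.

From the compounds shown here alone, it remains open whether the separation belongs to the oxygen of the methoxy, which a hydroxyl or a dimethylamino group at the same carbon would help to test, or whether a longer chain such as ethoxy would extend it. Going by these compounds, it is equally open whether a carboxylic acid at this carbon would stay within the same narrow band of values in this assay, and whether the naphthyl-free part of the shared core responds to exchanges in the same way.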